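The source may report more compounds than this note shows. Statements on the series, on what has been measured and on what is new or still open speak of the compounds shown alone.

In a functional assay on VCaP cells (Homo sapiens) for antiproliferative activity, read by propidium iodide staining, with a stated time of 96 h (on this read-out lower numbers stand for stronger inhibition and higher numbers for weaker inhibition), three compounds with a shared core have been measured. Compound 1 (`CC(O)(CSc1ccc(F)cc1)C(=O)Nc1cccc(S(F)(F)(F)(F)F)c1`) gives 21900 nM, compound 2 (`CC(O)(CSc1cccc(C(F)(F)F)c1)C(=O)Nc1cccc(S(F)(F)(F)(F)F)c1`) gives 20200 nM, and compound 3 (`CC(O)(CSc1cccc(OC(F)(F)F)c1)C(=O)Nc1cccc(S(F)(F)(F)(F)F)c1`) gives 17500 nM. Compound 2 thus stands within the scatter of both other compounds, so no order among the three can be read from these numbers.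

Compound 4 (`CC(O)(CSc1cc(C(F)(F)F)cc(C(F)(F)F)c1)C(=O)Nc1cccc(S(F)(F)(F)(F)F)c1`) departs from compound 2 at one place, where trifluoromethyl stands in place of hydrogen on an aromatic carbon: trifluoromethyl in place of hydrogen on an aromatic carbon. Two measured steps alter groups on that same ring: a 1.1-fold lower number from compound 1 to compound 2 (0.04 log units; within the scatter), and a 1.2-fold lower number from compound 2 to compound 3 (0.06 log units; within the scatter). Both are small and lie within the scatter, but neither adds a group to the ring in the way this change does, so they guide the expectation only loosely. No step beyond the scatter is therefore expected in this assay, in either direction. The estimated step is a 1.3-fold lower number from compound 2 to compound 4 (0.10 log units; within the scatter). For compound 4 the expected value is 16000 nM, with an estimated range of 8000 nM to 30000 nM.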

Compound 4, half-maximal inhibitory concentration: 4000 nM
Compound 4: the middle estimate sits 4.0-fold (0.60 log units) above what was measured, and the stated range ends above it.
By their numbers in this assay, from the lowest: compound 4; then compounds 3, 2 and 1 (each within the scatter of the next).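

In this assay, the six-membered aromatic ring responds to a group added at this position, not only to exchanges of its existing groups: trifluoromethyl in place of hydrogen gives a 5.1-fold lower number from compound 2 to compound 4 (0.70 log units; beyond the scatter). The earlier changes on this ring all stayed within the scatter, so this is the first step shown to lie beyond it, and it marks this position as one where the number can move, though only this single change shows it. Nothing at hand accounts for the size of this step.

On these data alone, what remains open is whether trifluoromethyl is needed here, or whether a chlorine atom, a nitrile or a methyl group at the same position would give a similar step. As far as these compounds go, whether the step depends on the trifluoromethyl group already on the ring also remains open.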